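A few compounds are considered here, and "the series" means these few. Any claim that something is new, unique, unknown or untested is made for them only; others in the source may bear on it.

Compound 3 `COc1ccc(C2CC(c3ccc(OC)c(OC)c3)=NN2C(=O)C(C)O[N+](=O)[O-])c(OC)c1` sits second highest of the three numbers in a functional assay on the whole organism (strain albino) for inhibition, with Rattus norvegicus as the target, read by paw edema, with stated times of 30 min and 2 h, at a dose of 100 mg/kg by the oral route (on this read-out higher numbers stand for more inhibition at the one dose given (going by the name of the read-out) and lower numbers for less inhibition), at 61%. Compound 1 `COc1ccc(C2CC(c3ccc(OC)c(OC)c3)=NN2C(=O)CBr)c(OC)c1` gives 67% and compound 2 `COc1ccc(C2CC(c3ccc(OC)c(OC)c3)=NN2C(=O)CO[N+](=O)[O-])c(OC)c1` gives 48%. The measured steps all alter the group on the carbonyl carbon: a number 19 percentage points lower from compound 1 to compound 2 (beyond the scatter), a number 6 percentage points lower from compound 1 to compound 3 (within the scatter) and a number 13 percentage points higher from compound 2 to compound 3 (beyond the scatter). Compound 4 `COc1ccc(C2CC(c3ccc(OC)c(OC)c3)=NN2C(=O)CNc2ccc(/C(C)=N/O)cc2)c(OC)c1` changes the same position, (a group of 12 heavy atoms (9 carbon, 2 nitrogen, 1 oxygen; one six-membered aromatic ring of carbon only) in place of a group of 6 heavy atoms (2 carbon, 1 nitrogen, 3 oxygen; no ring), on a carbonyl carbon). Within the data shown here, no measured step covers an entering group of this size or type, so the three steps at this position only bound the scale: two modest, one within the scatter. A step of that scale, with no direction favoured, is expected; compound 4 is estimated at 55%, range 38% to 72%, meaning an expected step of a number 6 percentage points lower from compound 3 to compound 4 (within the scatter).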

Compound 4, a percentage reported as inhibition, in the whole organism at one dose (the size of the read-out at that dose, not a potency): 44%
Beside the measured number, compound 4's estimate is 11 percentage points above it, and the stated range covers the measured number.
By their numbers in this assay, from the lowest: compounds 4 and 2 (each within the scatter of the next); then compounds 3 and 1 (each within the scatter of the next).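

In this assay, putting a group with a six-membered aromatic ring on the carbonyl carbon gives a number 17 percentage points lower from compound 3 to compound 4 (beyond the scatter) and a number 23 percentage points lower from compound 1 to compound 4 (beyond the scatter), so this position accepts the ring-bearing group with inhibition retained, though not at the level of these two compounds. The size of the group does not alone set the number: a number 4 percentage points lower from compound 2 to compound 4 (within the scatter), despite the far smaller group it replaces. No measurement here accounts for these steps. Still open, going by these compounds, is whether the ring, the nitrogen link or the oxime carries the step, and whether a carboxylic acid or a simple amine in that place would read differently.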